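Swapping the distal aryl ring of a lipophilicity series

The source may hold more compounds than are shown below. What is called first, only, known or untested is meant among the compounds shown, and "the series" means these compounds.

Measured compounds:
compound 1, `CC[C@@H](Nc1c(C#N)c(-c2ccc(-c3cccnc3C)cc2)nc2cnccc12)C(N)=O`: 1.9
compound 2, `CCOc1ccccc1-c1ccc(-c2nc3cnccc3c(N[C@H](CC)C(=O)NS(=O)(=O)C3CC3)c2C#N)cc1`: 2.3
compound 3, `CCOc1ccccc1-c1ccc(-c2nc3cnccc3c(N)c2C#N)cc1`: 3

In a physicochemical assay for lipophilicity, read by HPLC, at pH 7.5 (on this read-out lower numbers stand for lower lipophilicity and higher numbers for higher lipophilicity), compound 1 gives 1.9, the lowest of the three numbers; compound 2 gives 2.3 and compound 3 gives 3. Among the measured compounds shown here, the only step between two measured compounds that differ in one place runs from compound 2 to compound 3, where the read-out moved a number 0.70 log units higher from compound 2 to compound 3 (beyond the scatter) when a hydrogen atom replaced a larger group on a nitrogen on an aromatic ring.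

Compound 4, `CC[C@@H](Nc1c(C#N)c(-c2ccc(-c3ccccc3N(C)C)cc2)nc2cnccc12)C(N)=O`, has not been measured in this assay. It differs from compound 1 by 2-(dimethylamino)phenyl in place of 2-methylpyridin-3-yl on an aromatic carbon. For the measured compounds named here, the step from compound 2 to compound 3 concerns the group on the ring nitrogen and not the distal aryl ring, so no measured pair bears directly on this exchange. A modest rise is expected, a number 0.80 log units higher from compound 1 to compound 4 (beyond the scatter), and compound 4 is estimated at 2.7, within a range from 2.1 to 3.3.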

Compound 4, distribution coefficient: 3.2
Compound 4: the middle estimate sits 0.50 log units below what was measured, and the stated range covers the measured number.
By their numbers in this assay, from the lowest: compound 1; then compound 2; then compounds 3 and 4 (each within the scatter of the next).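

At the distal aryl position of compound 1, in this assay, the read-out moved a number 1.30 log units higher from compound 1 to compound 4 (beyond the scatter) when 2-(dimethylamino)phenyl replaced 2-methylpyridin-3-yl on an aromatic carbon para to a large group. Among the compounds shown here, this large step is the first seen at this position, and it exceeds the modest one at the ring nitrogen, a number 0.70 log units higher from compound 2 to compound 3 (beyond the scatter). Nothing measured here explains the rise.

The exchange replaces a six-membered aromatic ring with 1 hetero atom by one of carbon only and changes the ring's substituent as well, so the compounds shown cannot divide the step between these two differences. From the compounds shown here alone, a plain phenyl or a 2-methylphenyl group at this place would bear on that question, and whether the step holds with another group on the ring nitrogen remains open.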